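Replacing tert-butyl with cyclopropyl on an aromatic carbon

The compounds below may be only part of what the source reports. "The series", "measured", "known", "first", "only" and "open" are said of these compounds alone.

In an ADME assay on HFF cells (Homo sapiens) for cytotoxicity, read by MTT assay, with a stated time of 72 h (on this read-out higher numbers stand for weaker inhibition and lower numbers for stronger inhibition), compound 1 `COc1ccccc1-c1cn(C[C@H](O)[C@H]2OC(=O)C(OCc3ccccc3)=C2OCc2ccccc2)nn1` gives 50 nM and compound 2 `O=C1O[C@H]([C@@H](O)Cn2cc(CNS(=O)(=O)c3ccc(F)cc3)nn2)C(OCc2ccccc2)=C1OCc1ccccc1` gives 30 nM, two values within the scatter of each other. Compound 3 `CC(C)(C)c1cn(C[C@H](O)[C@H]2OC(=O)C(OCc3ccccc3)=C2OCc2ccccc2)nn1` has the highest number of the three, at 13300 nM. Compound 4 `O=C1O[C@H]([C@@H](O)Cn2cc(C3CC3)nn2)C(OCc2ccccc2)=C1OCc1ccccc1` carries cyclopropyl in place of tert-butyl on an aromatic carbon. Going by the values given here, two measured steps bear on this place, a 270-fold higher number from compound 1 to compound 3 (2.42 log units; beyond the scatter) and a 440-fold higher number from compound 2 to compound 3 (2.65 log units; beyond the scatter), both large and beyond the scatter. Among the compounds with values here, neither exchanges one small alkyl group for another, so no step of that size is expected in this assay. The expected change, slightly towards a lower number and within the scatter, is a 1.5-fold lower number from compound 3 to compound 4 (0.17 log units; within the scatter). Compound 4 is estimated at 9000 nM, with an expected range of 1500 nM to 30000 nM.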

Compound 4, half-maximal inhibitory concentration: 24300 nM
The estimate for compound 4 lay 2.7-fold (0.43 log units) below the measured number; the range from low to high includes it.
By their numbers in this assay, from the lowest: compounds 2 and 1 (each within the scatter of the next); then compounds 3 and 4 (each within the scatter of the next).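

In this assay the exchange of tert-butyl for cyclopropyl stays within the scatter (a 1.8-fold higher number from compound 3 to compound 4 (0.26 log units; within the scatter)), so the high numbers at this position are not confined to tert-butyl. Cyclopropyl also stands far from the 2-methoxyphenyl and (((4-fluorophenyl)sulfonyl)amino)methyl groups (a 490-fold higher number from compound 1 to compound 4 (2.69 log units; beyond the scatter); an 810-fold higher number from compound 2 to compound 4 (2.91 log units; beyond the scatter)). No measurement offered here accounts for this separation. The compounds shown leave open whether an amine, a carboxylic acid or a longer alkyl chain at this position would give numbers like those of compound 3 and compound 4 or those of compound 1 and compound 2.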